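The source may hold more compounds than are shown below. What is called first, only, known or untested is meant among the compounds shown, and "the series" means these compounds.

Measured compounds:
- compound 1, `COc1cc(Cc2nc3c(N)ncnc3n2CCCC(C)C)cc(OC)c1OC`: 69200 nM
- compound 2, `CCCn1c(Cc2cc(OC)c(OC)c(OC)c2)nc2c(N)nc(F)nc21`: 25100 nM

Both numbers come from a functional assay on MCF7 cells (Homo sapiens) for antiproliferative activity; on this read-out lower numbers stand for stronger inhibition and higher numbers for weaker inhibition. Compound 1 stands highest of the two measured compounds; compound 2 sits at a lower number, and the gap between them lies beyond the usual scatter of this assay. Going by the values given here, no pair of measured compounds differs in a single place, so no step has yet been quantified, and the two values give no guide to what any one substitution does.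

Compound 3, `COc1cc(Cc2nc3c(N)ncnc3n2CC(OC)OC)cc(OC)c1OC`, is not yet measured. Relative to compound 1 the change is dimethoxymethyl in place of isopentyl on a saturated chain carbon bound to an aromatic nitrogen. Nothing measured in the series bears on this exchange at the chain attached to the aromatic nitrogen, so the expectation rests on the size of the change alone and on compound 1 as the starting point at 69200 nM.

The step from compound 1 to compound 3 is expected to be small, a 1.2-fold lower number from compound 1 to compound 3 (0.06 log units; within the scatter), with no confident direction and possibly none beyond the scatter. For compound 3 the estimate in this assay is 60000 nM, within a range from 20000 nM to 180000 nM.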

Compound 3, half-maximal inhibitory concentration: 72400 nM
Compound 3: the middle estimate sits 1.2-fold (0.08 log units) below what was measured, within the range that was stated.
By their numbers in this assay, from the lowest: compound 2; then compounds 1 and 3 (each within the scatter of the next).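

In this assay, going by these compounds alone, dimethoxymethyl in place of isopentyl on a saturated chain carbon bound to an aromatic nitrogen gives a 1.0-fold higher number from compound 1 to compound 3 (0.02 log units; within the scatter), the first single-place step that can be read. Both groups hold 5 heavy atoms and no ring, while the entering group has 2 oxygen atoms and 2 hydrogen-bond acceptors against 0 of each in the leaving group, so at this position that exchange at equal heavy-atom count leaves the read-out within the scatter. No measured evidence bears on why compound 1 and compound 3 read alike.

Only this one exchange on the core of compound 1 is shown, so it remains open whether an amine, a carboxylic acid, a longer chain or a phenyl ring at this position would move the number beyond the scatter. Within the data shown here, compound 2 differs from compound 1 and from compound 3 in more than one place, so no step to it can be read, and whether the same exchange would also stay within the scatter on its core remains unknown.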